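Methoxy in place of difluoro on the aryl ketone

A few compounds are considered here, and "the series" means these few. Any claim that something is new, unique, unknown or untested is made for them only; others in the source may bear on it.

In a functional assay on MCF7 cells (Homo sapiens) for cytotoxicity, read by MTT assay, with a stated time of 48 h (on this read-out higher numbers stand for weaker inhibition and lower numbers for stronger inhibition), compound 1 `COc1cc(-c2nnc3n2NC(c2ccco2)C(C(=O)c2ccc(F)c(F)c2)S3)cc(OC)c1OC` gives 73200 nM. Compound 2 `COc1cc(-c2nnc3n2NC(c2cccs2)C(C(=O)c2ccc(F)cc2)S3)cc(OC)c1OC` differs from compound 1 in several places. In this assay compound 2 gives 43700 nM; the two numbers lie within the scatter of one another, so neither compound stands apart. Compound 3 `COc1ccc(C(=O)C2Sc3nnc(-c4cc(OC)c(OC)c(OC)c4)n3NC2c2ccco2)cc1` carries 4-methoxyphenyl in place of 3,4-difluorophenyl on a carbonyl carbon. Among the compounds with values here, no measured pair shows this change, so nothing is known of its effect. The expected step of a 1.2-fold lower number from compound 1 to compound 3 (0.09 log units; within the scatter) is small and not beyond the scatter. Compound 3 is therefore estimated at 60000 nM, within a range from 25000 nM to 150000 nM.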

Compound 3, half-maximal inhibitory concentration: > 100000 nM
Compound 3: a limit, no number; the forecaster's own chance of this, stated with the estimate: 20%; middle value at least 1.6-fold (0.22 log units) away from the limit.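

In this assay compound 3 gives > 100000 nM, which is a limit of the assay and not a number. This is the first change in one place among these compounds, 4-methoxyphenyl in place of 3,4-difluorophenyl on a carbonyl carbon, and it reads as an at least 1.3-fold higher number from compound 1 to compound 3 (0.13 log units; that floor lies within the scatter). From the compounds shown here alone, only a floor is available, so the change shows no gain in this assay, while the true size of the step stays unknown: the limit of > 100000 nM in this assay, at which 1 of the 3 values shown sits.

The compounds shown leave open how an amine or a carboxylic acid in place of the methoxy group would read at this position.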